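The source may report more compounds than this note shows. Statements on the series, on what has been measured and on what is new or still open speak of the compounds shown alone.

Measured compounds:
- compound 1, `COc1cc(C)cc(-c2nn(CC#N)cc2-c2ccc(-c3cccc(C(C)=O)c3)nc2)c1`, 94%
- compound 2, `Cc1cc(O)cc(-c2nn(CC#N)cc2-c2ccnc(-c3ccc(Oc4ccccc4)cc3)c2)c1`, 95%
- compound 3, `COc1cc(C)cc(-c2nn(CC#N)cc2-c2ccnc(-c3ccc(N(C)C)cc3)c2)c1`, 90%

All three were read in a functional assay on UACC-257 cells (Homo sapiens) for cytotoxicity, read by sulforhodamine B assay, with a stated time of 48 h, tested at 0.001 uM; a higher number here means a weaker effect of the compound at the concentration tested, a lower number a stronger effect. In this assay compound 3 gives 90%, compound 1 gives 94% and compound 2 gives 95%. The number for compound 3 sits at the lower edge of the three, but its distances to compound 1 and to compound 2 are both within the usual scatter, so no order among them can be read from these data; the three stand together as weakly acting at this concentration.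

Compound 4, `Cc1cc(O)cc(-c2nn(CC#N)cc2-c2ccnc(-c3ccc(N(C)C)cc3)c2)c1`, has not been measured. It differs from compound 3 in one place: hydrogen in place of methyl on an oxygen on an aromatic ring. Seen one bond further out, this is methoxy to hydroxy, 3-methoxy-5-methylphenyl to 3-hydroxy-5-methylphenyl. No measured pair shows this change on its own, so no size can be taken from a shown step. Compound 2 already carries the 3-hydroxy-5-methylphenyl group and gives 95%, which lies in the same band as compound 3. Because compound 2 gives 95%, a step of no size beyond the scatter is expected, in either direction, a number 3 percentage points higher from compound 3 to compound 4 (within the scatter). Compound 4 is therefore estimated at 93%, within 83% to 100%.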

Compound 4, a percentage reported as activity, at one concentration (the size of the read-out at that concentration, not a potency): 96%
Compound 4: the middle estimate sits 3 percentage points below what was measured, and the stated range covers the measured number.
By their numbers in this assay, from the lowest: compounds 3, 1, 2 and 4 (each within the scatter of the next).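

In this assay the swap on the oxygen on the aromatic ring can now be read on its own, with the dimethylamino group held fixed: methoxy to hydroxy gives a number 6 percentage points higher from compound 3 to compound 4 (within the scatter) and cannot be told apart from no effect at this concentration. With 3-hydroxy-5-methylphenyl held fixed, dimethylamino in place of phenoxy on an aromatic carbon gives a number 1 percentage points higher from compound 2 to compound 4 (within the scatter) and can likewise not be told apart from no effect. No data shown here bear on the reason for either result.

On these data alone, whether an amine or a carboxylic acid in place of the hydroxy, or a longer chain such as ethoxy on the oxygen, would give a step beyond the scatter stays open. Also open, as far as these compounds go, is whether these two readings hold at any concentration other than the single one tested.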